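A few compounds are considered here, and "the series" means these few. Any claim that something is new, unique, unknown or untested is made for them only; others in the source may bear on it.

Among the measured compounds shown here, in a functional assay on MCF7 cells (Homo sapiens) for antiproliferative activity, read by MTT assay, with a stated time of 48 h (on this read-out lower numbers stand for stronger inhibition and higher numbers for weaker inhibition), compound 1 `Cc1ccc(C(=O)/C=C/c2cc(Br)cc(Br)c2Oc2c([N+](=O)[O-])cc(C(F)(F)F)cc2[N+](=O)[O-])cc1` gives 1.44 ug/mL, the middle of the three numbers so far. Compound 2 `Cc1ccc(C(=O)/C=C/c2cccc(Br)c2Oc2c([N+](=O)[O-])cc(C(F)(F)F)cc2[N+](=O)[O-])cc1` gives 0.55 ug/mL, and compound 3 `O=C(/C=C/c1cccc(Cl)c1Oc1c([N+](=O)[O-])cc(C(F)(F)F)cc1[N+](=O)[O-])c1ccc(F)cc1` gives 5.17 ug/mL. The next structure to read is compound 4 `O=C(/C=C/c1cc(Br)cc(Br)c1Oc1c([N+](=O)[O-])cc(C(F)(F)F)cc1[N+](=O)[O-])c1ccc(Br)cc1`, which departs from compound 1 at one place: bromo in place of methyl on an aromatic carbon. This is bromo in place of methyl on an aromatic carbon, para to a large group, so 4-methylphenyl becomes 4-bromophenyl.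

For the measured compounds named here, the only measured single-place step is a 2.6-fold lower number from compound 1 to compound 2 (0.42 log units; beyond the scatter), a modest move with hydrogen in place of bromo on an aromatic carbon. That step does not touch the 4-methylphenyl, so it serves only as a guide to size. Compound 3 differs from compound 1 in more than one place, and what compound 3 gives at 5.17 ug/mL cannot be assigned to any single change. Going by the values given here, no measured pair isolates the methyl-to-bromo change, so the data give no firm direction, and no step beyond the scatter is expected as the central case in this assay. The expected step is a 1.2-fold higher number from compound 1 to compound 4 (0.07 log units; within the scatter), with a wide margin on either side. For compound 4 the estimate is 1.7 ug/mL, with an expected range of 0.6 ug/mL to 4.8 ug/mL.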

Compound 4, half-maximal inhibitory concentration: 2.87 ug/mL
For compound 4 the middle estimate is 1.7-fold (0.23 log units) below the measured one; measured number inside the range.
By their numbers in this assay, from the lowest: compound 2; then compounds 1, 4 and 3 (each within the scatter of the next, the first and the last beyond it).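

In this assay, among the compounds shown here, the swap of methyl for bromo on this aromatic carbon, para to a large group, gives the first reading at the 4-methylphenyl end of the series: a 2.0-fold higher number from compound 1 to compound 4 (0.30 log units; within the scatter). For the compounds shown here, this place therefore accepts 4-bromophenyl in place of 4-methylphenyl without a step beyond the scatter, whereas the only earlier single-place step, at the other aromatic ring, is printed as beyond it: a 2.6-fold lower number from compound 1 to compound 2 (0.42 log units; beyond the scatter). The data at hand offer no measurement that explains the size of either step.

As far as these compounds go, only methyl and bromo can be compared directly at this place, so it remains open whether a group of another kind, such as an amine, a carboxylic acid or a longer alkyl chain, would stay within the scatter of compound 1 or move the number well beyond it. Going by these compounds alone, it also remains open whether the same methyl-to-bromo swap would give a step of similar size on the core of compound 2, which has the lowest number so far.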